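The source may report more compounds than this note shows. Statements on the series, on what has been measured and on what is new or still open speak of the compounds shown alone.

Measured in a functional assay on A549 cells (Homo sapiens) for antiproliferative activity, read by MTT assay, with a stated time of 48 h (a higher number here means a weaker inhibitor, a lower number a stronger inhibitor), so far

Compound 1 `CCCCC1(O)C(=O)Nc2ccc(Nc3ccc(F)cc3)cc21` gives 6500 nM
Compound 2 `CCCCCCC1(O)C(=O)Nc2ccc(Nc3ccc(F)cc3)cc21` gives 12000 nM
Compound 3 `CCCCC1(O)C(=O)Nc2ccc(Nc3ccc(Cl)cc3)cc21` gives 2800 nM

Among these three, compound 3 has the lowest number in this assay and is the strongest inhibitor of the set, ahead of both other compounds by more than the usual scatter. Within the data shown here, the next candidate is compound 4 `CCCCCCC1(O)C(=O)Nc2ccc(Nc3ccc(Cl)cc3)cc21`, which has no measurement yet. Its structure departs from compound 3 in one place (ethyl in place of hydrogen on a saturated chain carbon, four bonds along the chain from a saturated ring carbon), with ethyl in place of hydrogen on a saturated chain carbon, four bonds along the chain from a saturated ring carbon.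

The same change has been measured once, in the fluoro series (a 1.8-fold higher number from compound 1 to compound 2 (0.27 log units; within the scatter)). That single step is small and points towards a higher number. The other measured step (a 2.3-fold lower number from compound 1 to compound 3 (0.37 log units; beyond the scatter)) is chloro in place of fluoro on an aromatic carbon. Among the measured compounds shown here, this exchange plays no part in the new step, since compound 3 and compound 4 both carry chloro, and no measured pair shows whether the ethyl step depends on that halogen.

A small rise in this assay is therefore expected, probably not beyond the scatter (a 1.7-fold higher number from compound 3 to compound 4 (0.23 log units; within the scatter)). For compound 4 the estimated value is 4800 nM, with an expected range from 2000 nM to 11000 nM.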

Compound 4, half-maximal inhibitory concentration: 5400 nM
Compound 4: middle estimate off by 1.1-fold (0.05 log units), on the low side; measured number inside the range.
By their numbers in this assay, from the lowest: compounds 3, 4, 1 and 2 (each within the scatter of the next, the first and the last beyond it).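

In this assay, the ethyl in place of hydrogen on a saturated chain carbon, four bonds along the chain from a saturated ring carbon, has now also been read in the chloro series, a 1.9-fold higher number from compound 3 to compound 4 (0.29 log units; within the scatter), so this step no longer rests on the fluoro series alone and stays within the scatter on both cores: the same change on two cores in this assay, a 1.8-fold higher number (0.27 log units; within the scatter) from compound 1 to compound 2 and a 1.9-fold higher number (0.29 log units; within the scatter) from compound 3 to compound 4, 1.0-fold (0.02 log units) apart, within the scatter of two such steps. Among these compounds, the chloro in place of fluoro exchange, earlier seen only on the shorter chain, has now been read on the longer chain as well, a 2.2-fold lower number from compound 2 to compound 4 (0.35 log units; beyond the scatter), and it stays beyond the scatter, though modest, on both cores: the same change on two cores in this assay, a 2.3-fold lower number (0.37 log units; beyond the scatter) from compound 1 to compound 3 and a 2.2-fold lower number (0.35 log units; beyond the scatter) from compound 2 to compound 4, 1.0-fold (0.02 log units) apart, within the scatter of two such steps. Across these four compounds, neither change alters the size of the other, so the chain step shows no dependence on the halogen, and the halogen step shows none on the chain.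

The compounds shown leave open whether a bromo or trifluoromethyl group in the halogen's place would give a lower number than chloro does. They also leave open how a much longer chain, or a chain ending in an amine or a carboxylic acid, would read at this position.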